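Triazole nitrogen substituent: phenyl to fluorophenylcarbamoylmethyl

A few compounds are considered here, and "the series" means these few. Any claim that something is new, unique, unknown or untested is made for them only; others in the source may bear on it.

Compound 3 `CCOC(=O)C1=Cc2ccccc2OC1(OCc1cn(-c2ccccc2)nn1)C(F)(F)F` in a functional assay on A549 cells (Homo sapiens) for inhibition, read by MTT assay, with a stated time of 24 h (a lower number here means a stronger inhibitor, a higher number a weaker inhibitor), gives > 150000 nM, which is a limit of the assay and not a number. Compound 1 `CCOC(=O)C1=Cc2ccccc2OC1(OCc1cn(-c2cccc(OC)c2)nn1)C(F)(F)F` in this assay gives > 150000 nM, likewise a limit. Compound 2 `CCOC(=O)C1=Cc2ccccc2OC1(OCc1cn(CC(=O)NC2CCCCC2)nn1)C(F)(F)F` in this assay gives 9900 nM. Within the data shown here, the two steps that reach a number are an at least 15-fold lower number from compound 1 to compound 2 (1.18 log units; beyond the scatter) and an at least 15-fold higher number from compound 2 to compound 3 (1.18 log units; beyond the scatter); in both, the compound with the (cyclohexylcarbamoyl)methyl group on the aromatic nitrogen is the one with the measurable value, while the limit of > 150000 nM in this assay, at which 2 of the 3 values shown sit, covers the two aryl-substituted compounds. Compound 4 `CCOC(=O)C1=Cc2ccccc2OC1(OCc1cn(CC(=O)Nc2ccccc2F)nn1)C(F)(F)F` is not yet measured; it differs from compound 3 in ((2-fluorophenyl)carbamoyl)methyl in place of phenyl on an aromatic nitrogen. This change again places a carbamoylmethyl group on the ring nitrogen, as in compound 2, though with a 2-fluorophenyl rather than a cyclohexyl on the amide. A large step downward in this assay is therefore expected for compound 4, of about an at least 7.5-fold lower number from compound 3 to compound 4 (0.87 log units; beyond the scatter), with the remaining uncertainty being whether the aryl amide reaches a number at all. Compound 4 is estimated at 20000 nM in this assay, between 5000 nM and 150000 nM.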

Compound 4, half-maximal inhibitory concentration: 50100 nM
Beside the measured number, compound 4's estimate is 2.5-fold (0.40 log units) below it, and the stated range covers the measured number.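

With compound 4, a measurable value on the aromatic nitrogen is no longer tied to the cyclohexyl amide of compound 2, as ((2-fluorophenyl)carbamoyl)methyl gives an at least 2.9-fold lower number from compound 3 to compound 4 (0.47 log units; beyond the scatter) and an at least 2.9-fold lower number from compound 1 to compound 4 (0.47 log units; beyond the scatter) in this assay. The amide substituent still counts at this position, with 2-fluorophenyl in place of cyclohexyl giving a 5.1-fold higher number from compound 2 to compound 4 (0.70 log units; beyond the scatter). Compound 1 and compound 3, with an aryl group directly on the aromatic nitrogen, remain at a limit and not a number: the limit of > 150000 nM in this assay, at which 2 of the 4 values shown sit.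

The compounds shown do not separate the contribution of the fluorine from that of the aromatic ring on the amide, so a plain phenyl amide remains an open comparison. Also open, as far as these compounds go, is whether a longer chain carrying the amide, or an amine or a carboxylic acid in place of the amide, would hold a measurable value.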